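A few compounds are considered here, and "the series" means these few. Any claim that something is new, unique, unknown or untested is made for them only; others in the source may bear on it.

Compound 1 `CCSC(=S)N[C@H]1CCOC1=O` gives, in a functional assay on MGC-803 cells (Homo sapiens) for cytotoxicity, read by MTT assay, with a stated time of 72 h (a lower number here means a stronger inhibitor, a higher number a weaker inhibitor), a value that is only a limit: > 128000 nM.
Compound 2 `O=C(CCl)Nc1ccc(C(=O)/C=C/c2ccc(Br)cc2)cc1` gives in this assay 6050 nM.

Among the measured compounds shown here, compound 2 is the one compound here with an actual number in this assay; the other value shown is a limit, not a number, as the limit of > 128000 nM in this assay, at which 1 of the 2 values shown sits, records for compound 1. For the measured compounds named here, nothing beyond that single number and that limit is known, so there is no measured step between two compounds from which the effect of a structural change could be read.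

Compound 3 `Cc1ccc(/C=C/C(=O)c2ccc(NC(=O)CCl)cc2)cc1` has not been measured yet. It differs from compound 2 in one place: methyl in place of bromo on an aromatic carbon. Going by the values given here, with no measured step to lean on, the expectation for this assay rests on compound 2 alone, and the change is a small one at the outer edge of the molecule. The step from compound 2 to compound 3 is expected to be modest, most likely within the usual scatter, with no firm direction: a 1.3-fold higher number from compound 2 to compound 3 (0.12 log units; within the scatter). Compound 3 is therefore estimated at 8000 nM, with a range from 2500 nM to 25000 nM.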

Compound 3, half-maximal inhibitory concentration: 3600 nM
The estimate for compound 3 lay 2.2-fold (0.35 log units) above the measured number; low and high end bracket the measured number.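

Among the compounds shown here, this is the first measured step in the set: in this assay, replacing 4-bromophenyl with 4-methylphenyl gives a 1.7-fold lower number from compound 2 to compound 3 (0.23 log units; within the scatter), which lies within the usual scatter of repeated measurements. At this place on the aromatic ring, para to a large group, bromo and methyl therefore cannot be told apart by this read-out, so neither group can be called the better one, and the swap of one heavy atom for another leaves the cytotoxicity reading of the shared core effectively where it was. The values shown offer nothing that speaks to why these two groups read alike.

What the compounds shown leave open is whether this place stays just as indifferent to groups of a different kind, such as an amine, a carboxylic acid or a longer chain like butyl, any of which could shift the number well beyond the scatter. Also open, on these data alone, is how the number responds to a change made anywhere else on the shared core, as this single step speaks only to this one position.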